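Ester series: side-chain swap at the amino acid position

The compounds below may be only part of what the source reports. "The series", "measured", "known", "first", "only" and "open" are said of these compounds alone.

Compound 1 `C[C@H](NC(=O)CN(c1nc(Cl)nc2[nH]cnc12)C1CC1)C(=O)OCc1ccccc1` gives 36.1% in a functional assay on the whole organism (Tail, strain ICR) with Mus musculus as the target, in the tail flick test, with a stated time of 120 min, at a dose of 25 umol/kg by the oral route; a lower number here means a weaker effect, a higher number a stronger effect of the compound at the dose given. Compound 2 `NCCCC[C@H](NC(=O)CN(c1nc(Cl)nc2[nH]cnc12)C1CC1)C(=O)OCc1ccccc1` gives 16.8% in this assay. Among the compounds with values here, the one step measured so far, a number 19.3 percentage points lower from compound 1 to compound 2 (beyond the scatter), is the only comparison available, and compound 2 stands lowest of the two numbers, with compound 1 as its nearest neighbour.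

Compound 3 `NC(=O)CC[C@H](NC(=O)CN(c1nc(Cl)nc2[nH]cnc12)C1CC1)C(=O)OCc1ccccc1` differs from compound 2 by carbamoyl in place of 2-aminoethyl on a saturated chain carbon, three bonds along the chain from an amide-type nitrogen and a carbonyl carbon. The measured step bears on this only indirectly: it shows that lengthening the chain at this position by 3-aminopropyl lowered the read-out by a modest amount, whereas here the chain is shortened and the terminal group exchanged. Within the data shown here, no measured pair covers that exchange, so the direction is uncertain; a small change, possibly back toward compound 1, or none beyond the scatter, is the expectation.

Compound 3 is therefore expected to give 22%, within a range from 8% to 40%. The expected step is a number 5.2 percentage points higher from compound 2 to compound 3 (within the scatter).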

Compound 3, a percentage reported as activity, at one dose (the size of the read-out at that dose, not a potency): 36%
Beside the measured number, compound 3's estimate is 14 percentage points below it; low and high end bracket the measured number.
By their numbers in this assay, from the lowest: compound 2; then compounds 3 and 1 (each within the scatter of the next).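

Exchanging 2-aminoethyl for carbamoyl at this position gives a number 19.2 percentage points higher from compound 2 to compound 3 (beyond the scatter) in this assay, so the read-out depends on what the side chain carries and not only on its presence. Carbamoylmethyl in place of hydrogen gives a number 0.1 percentage points lower from compound 1 to compound 3 (within the scatter), which means that a longer chain at this carbon does not in itself go with a lower read-out; of the three compounds, only compound 2, with its terminal amine, stands apart. No measurement at hand accounts for the difference between the amine and the carbamoyl chain.

Still open, on these data alone, is whether a carboxylic acid in place of carbamoyl, or a plain alkyl chain of the same length, would group with compound 3 or with compound 2. With a single dose and a single time point, these numbers also leave relative potency unresolved.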